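Pyridin-2-yl for pyrimidin-2-yl: notes before the measurement

This account rests on a few compounds, and the source may have more. Where it says the series, first, only, none or still open, it means among the compounds named here.

Three compounds of the series have numbers in an ADME assay on L6 cells (Rattus norvegicus) for cytotoxicity; a higher number here means a weaker inhibitor, a lower number a stronger inhibitor. Compound 1 `O=C(Cn1ccnc1[N+](=O)[O-])N1CCN(c2ncccn2)CC1` gives 280000 nM. Compound 2 `O=C(Cn1cnc([N+](=O)[O-])n1)N1CCN(c2ncccn2)CC1` gives 150000 nM. Compound 3 `O=C(CN1CCN(c2ccc(Cl)c(Cl)c2)CC1)N1CCN(c2ccc(Cl)c(Cl)c2)CC1`, built differently from the other two, gives 20200 nM.

Compound 2 stands second highest of the three numbers. Its nearest neighbour is compound 1, whose value lies within the usual scatter of repeated measurement, so no order can be read between compound 1 and compound 2. Its furthest neighbour is compound 3, whose lower number lies beyond the scatter.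

Compound 4 `O=C(Cn1cnc([N+](=O)[O-])n1)N1CCN(c2ccccn2)CC1` has not yet been measured in this assay. Against compound 2 the change is pyridin-2-yl in place of pyrimidin-2-yl on an amine nitrogen in a ring. Within the data shown here, no pair of measured compounds differs in exactly this way, so there is no measured step to lean on. The group that enters has the same number of heavy atoms and the same ring size as the group that leaves, and the change sits on an amine nitrogen in a ring far from where compounds 1 and 2 already differ. The expected step from compound 2 to compound 4 is therefore small, a 1.2-fold lower number from compound 2 to compound 4 (0.06 log units; within the scatter), and not beyond the scatter in either direction. Compound 4 is expected to give about 130000 nM in this assay, with a range from 55000 nM to 300000 nM.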

Compound 4, half-maximal inhibitory concentration: 173000 nM
The estimate for compound 4 lay 1.3-fold (0.12 log units) below the measured number, and the stated range covers the measured number.
By their numbers in this assay, from the lowest: compound 3; then compounds 2, 4 and 1 (each within the scatter of the next).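

Among these compounds, the swap gives the only step between compounds that differ in one place. In this assay, pyridin-2-yl in place of pyrimidin-2-yl on an amine nitrogen in a ring gives a 1.2-fold higher number from compound 2 to compound 4 (0.06 log units; within the scatter), so no order can be read between the two compounds, although the hydrogen-bond acceptor count of the group goes from 2 to 1 and its 6 heavy atoms stay the same. No separate measurement on these compounds bears on this result, and the step stands here as an observation on a single pair.

As far as these compounds go, it remains open whether a phenyl group, or a pyridin-2-yl carrying an amine or a carboxylic acid, at this place would also stay within the scatter of compound 2. From the compounds shown here alone, it is equally open whether the same swap would give a step of similar size on the core of compound 1, and compound 3, which differs from compound 2 in more than one place, cannot answer either question.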